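Putting 2,4-dihydroxyphenyl in place of 4-methoxyphenyl

The compounds below may be only part of what the source reports. "The series", "measured", "known", "first", "only" and "open" are said of these compounds alone.

In a functional assay on MCF7 cells (Homo sapiens) for inhibition, read by MTT assay, with a stated time of 72 h (on this read-out higher numbers stand for weaker inhibition and lower numbers for stronger inhibition), compound 1 `COc1cc(OC)c(OC)cc1/C=C/C(=O)c1cc(OC(C)=O)ccc1OC(C)=O` gives 63700 nM and compound 2 `COc1ccc(C(=O)/C=C/c2cc(OC)c(OC)cc2OC)cc1` gives 33900 nM so the two lie within the scatter of each other. For compound 3 `COc1cc(OC)c(OC)cc1/C=C/C(=O)c1ccc(-c2c[nH]cn2)cc1` only a limit is reported (> 150000 nM). Compound 2 therefore stands level with compound 1, and no order can be drawn between them.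

Compound 4 `COc1cc(OC)c(OC)cc1/C=C/C(=O)c1ccc(O)cc1O` differs from compound 2 by one change on a carbonyl carbon, with 2,4-dihydroxyphenyl in place of 4-methoxyphenyl (2,4-dihydroxyphenyl in place of 4-methoxyphenyl on a carbonyl carbon). For the measured compounds named here, only one measured step starts from compound 2 (an at least 4.4-fold higher number from compound 2 to compound 3 (0.64 log units; beyond the scatter)) and it lies beyond the scatter. Its size rests on the limit of > 150000 nM in this assay, at which 1 of the 3 values shown sits, and so it is a bound rather than an exact figure. Going by the values given here, that step also brings in a different group from the one in compound 4, and no measured compound carries 2,4-dihydroxyphenyl. Its size and direction are therefore not carried over, and no change beyond the scatter is expected in this assay for this swap. The expected step is a 1.4-fold lower number from compound 2 to compound 4 (0.13 log units; within the scatter) and it is estimated to stay within the scatter. Compound 4 is expected at 25000 nM with an estimated range from 8000 nM to 80000 nM once it is measured.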

Compound 4, half-maximal inhibitory concentration: 33800 nM
Beside the measured number, compound 4's estimate is 1.4-fold (0.13 log units) below it; low and high end bracket the measured number.
By their numbers in this assay, from the lowest: compounds 4, 2 and 1 (each within the scatter of the next). At a limit, above all of these: compound 3.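

In this assay, the swap to 2,4-dihydroxyphenyl in place of 4-methoxyphenyl on a carbonyl carbon leaves the number where it was: a 1.0-fold lower number from compound 2 to compound 4 (0.00 log units; within the scatter). For the compounds shown here, this is the first step from compound 2 with an exact number at both ends, since the earlier at least 4.4-fold higher number from compound 2 to compound 3 (0.64 log units; beyond the scatter) gave only a bound. Here, 2,4-dihydroxyphenyl brings 2 hydrogen-bond donors where 4-methoxyphenyl has 0, yet the step stays within the scatter, and nothing measured here gives a cause for that.

On these data alone, whether an amine or a carboxylic acid on this ring would carry the number beyond the scatter remains open, as does whether a single hydroxyl group would give the same number as 2,4-dihydroxyphenyl. No compound shown stands beyond the scatter below compound 2, so the compounds leave open which change at this place, if any, would give stronger inhibition.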